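Acetyl for fluoro beside the pyridine-type nitrogen

The compounds below may be only part of what the source reports. "The series", "measured", "known", "first", "only" and "open" are said of these compounds alone.

In an in vitro functional assay on HEK293-A cells for agonist activity at metabotropic glutamate receptor 5 (Rattus norvegicus), read by ELISA (a higher number here means a weaker inhibitor, a lower number a stronger inhibitor), compound 1 `COc1cc(C#N)cc(C#Cc2cccc(C)n2)c1` gives 3.4 nM. Compound 2 `CCc1cccc(C#Cc2cccc(C#N)c2)n1` gives 80 nM in this assay. Compound 3 `N#Cc1cc(F)cc(C#Cc2cccc(F)n2)c1` gives 80 nM in this assay, level with compound 2 within the scatter; together these two hold the highest numbers of the three, while the number for compound 1 lies well below, beyond the scatter. Compound 4 `CC(=O)c1cccc(C#Cc2cc(F)cc(C#N)c2)n1` has not been measured; it differs from compound 3 by acetyl in place of fluoro on an aromatic carbon. Among the measured compounds shown here, no measured pair in this assay carries that change, so its direction is open. A step from compound 3 to compound 4 of about a 1.1-fold lower number from compound 3 to compound 4 (0.06 log units; within the scatter) is expected, small and within the scatter. Compound 4 is estimated at 70 nM, in the range 15 nM to 350 nM.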

Compound 4, half-maximal inhibitory concentration: 240 nM
Estimate against measurement, compound 4: 3.4-fold (0.54 log units) below, and the stated range covers the measured number.
By their numbers in this assay, from the lowest: compound 1; then compounds 2 and 3 (each within the scatter of the next); then compound 4.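

Acetyl in place of fluoro on an aromatic carbon next to the ring nitrogen gives a 3.0-fold higher number from compound 3 to compound 4 (0.48 log units; beyond the scatter) and so supplies the first single-place comparison in the series. The position responds to this change, yet compound 4, with 3 heavy atoms and a hydrogen-bond acceptor in the entering group, still gives a measurable number in this assay. Nothing on hand accounts for the step. Going by these compounds, whether the carbonyl or the group's size sets the step remains open, as does the outcome for an amine, a carboxylic acid or a longer acyl chain here. Also open, on these data alone, is whether the step holds with methoxy in place of fluoro on the nitrile-bearing ring.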